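Adding a Nitro Group to Compound 3

The source may report more compounds than this note shows. Statements on the series, on what has been measured and on what is new or still open speak of the compounds shown alone.

Measured so far in a functional assay on HepG2 cells (Homo sapiens) for cytotoxicity, read by MTT assay, with a stated time of 24 h (a lower number here means a stronger inhibitor, a higher number a weaker inhibitor), are three compounds
- compound 1 `COc1cc(/C=C2\CN(C)C/C(=C\c3cccnc3)C2=O)cc(OC)c1OC` gives 9520 nM
- compound 2 `COc1ccc(/C=C2\CN(C)C/C(=C\c3cccnc3)C2=O)c(OC)c1OC` gives 5160 nM
- compound 3 `CN1C/C(=C\c2cccnc2)C(=O)/C(=C/c2ccccc2F)C1` gives 4810 nM

Compound 3 stands within the usual scatter of both compound 2 and compound 1, so these three cannot be ranked. Compound 4 `CN1C/C(=C\c2cccnc2)C(=O)/C(=C/c2cc([N+](=O)[O-])ccc2F)C1` is compound 3 with nitro in place of hydrogen on an aromatic carbon, para to a fluoro group (nitro in place of hydrogen on an aromatic carbon). Among the compounds with values here, no measured pair differs in one place only, so the data give no direct measure of this change. The expectation therefore starts from compound 3 at 4810 nM and stays close to it. The expected step of a 1.3-fold lower number from compound 3 to compound 4 (0.10 log units; within the scatter) lies within the scatter, with a slight lean toward a lower number. Compound 4 is estimated at 3800 nM with 1500 nM to 9000 nM as the expected range.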

Compound 4, half-maximal inhibitory concentration: 6630 nM
Compound 4: the middle estimate sits 1.7-fold (0.24 log units) below what was measured; measured number inside the range.
By their numbers in this assay, from the lowest: compounds 3, 2, 4 and 1 (each within the scatter of the next).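

In this assay, within the data shown here, nitro in place of hydrogen on an aromatic carbon, para to a fluoro group, gives a 1.4-fold higher number from compound 3 to compound 4 (0.14 log units; within the scatter) and this is the first pair here that differs in one place only. At this position, then, a nitro group of 3 heavy atoms leaves a difference that cannot be told from repeat-measurement noise. Nothing measured here speaks to the reason for this result.

From the compounds shown here alone, whether an amine or a carboxylic acid on this same carbon would give a step beyond the scatter remains open. So does whether nitro would give a similar step elsewhere on this ring.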